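The compounds below may be only part of what the source reports. "The series", "measured", "known", "first", "only" and "open" are said of these compounds alone.

Compound 1 `Cc1ncnc2c1c(I)cn2[C@@H]1O[C@H](CO)[C@@H](O)[C@H]1O` is the starting point. Among the compounds with values here, in a functional assay on CEM-DNR-bulk cells (Homo sapiens), read by MTT assay, with a stated time of 72 h (a higher number here means a weaker inhibitor, a lower number a stronger inhibitor), compound 1 gives 12600 nM, the only plain number that appears here. Compound 2 `Cc1nc(N)c2c(-c3ccoc3)cn([C@@H]3O[C@H](CO)[C@@H](O)[C@H]3O)c2n1` shares the same sugar but carries a different core. In this assay compound 2 gives > 20000 nM, which is a limit of the assay rather than a number; this is the limit of > 20000 nM in this assay, at which 1 of the 2 values shown sits. Within the data shown here, no two of the measured compounds differ in one place only, so no measured step is available.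

Compound 3 `Cc1ncnc2c1c(-c1ccsc1)cn2[C@@H]1O[C@H](CO)[C@@H](O)[C@H]1O` has not been measured. It differs from compound 1 in one place: thiophen-3-yl in place of iodo on an aromatic carbon. Compound 2, which also carries a five-membered aromatic ring with 1 hetero atom, gives only the limit > 20000 nM in this assay, so for compound 3 a small step toward weaker inhibition, or none beyond the usual scatter, is expected in this assay. The expected step is a 1.3-fold higher number from compound 1 to compound 3 (0.10 log units; within the scatter). Compound 3 is therefore estimated at 16000 nM, within 4000 nM to 60000 nM, with a real chance that only a limit is reported.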

Compound 3, half-maximal inhibitory concentration: 8560 nM
Compound 3: middle estimate off by 1.9-fold (0.27 log units), on the high side; measured number inside the range.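

Replacing iodo, 1 heavy atom, with thiophen-3-yl, 5 heavy atoms including a ring, gives in this assay a 1.5-fold lower number from compound 1 to compound 3 (0.17 log units; within the scatter). This aromatic carbon of the shared core therefore accepts a much larger group, at least this one, with no difference beyond the usual scatter, and a five-membered aromatic ring with 1 hetero atom at this place can still give a plain number. Compound 2 also has such a ring at this place, but it differs from compound 3 in more than one place and gives only a limit of the assay, so no step can be read from it: the limit of > 20000 nM in this assay, at which 1 of the 3 values shown sits.

From the compounds shown here alone, what a carboxylic acid, a longer alkyl chain or a six-membered phenyl ring would do at this carbon remains open, so two groups give only a narrow view of the position. Also open, going by these compounds, is what the different core of compound 2 contributes on its own, as it appears there together with a different ring.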